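Imidazole substituent series: replacing the 4-cyanophenyl with propyl

The source may report more compounds than this note shows. Statements on the series, on what has been measured and on what is new or still open speak of the compounds shown alone.

Measured compounds:
compound 1 `O=C(O)c1ccccc1-c1ccc(CCc2ncc(CC3CCC3)[nH]2)cc1`, an in vitro functional assay on cells for agonist activity at Bombesin receptor subtype-3 (Homo sapiens), read by luminescence and calcium flux; a lower number here means that less compound is needed, a higher number that more compound is needed for the effect: 588 nM
compound 2 `CCCCc1cnc(C(CCCC)Cc2ccc(-c3ccccc3C(=O)O)cc2)[nH]1`, this assay: 2660 nM
compound 3 `N#Cc1ccc(Cc2cnc(CCc3ccc(-c4ccccc4C(=O)O)cc3)[nH]2)cc1`, this assay: 5890 nM

Compound 3 stands highest of the three numbers in this assay. Its nearest neighbour is compound 2, which gives 2660 nM, a gap beyond the scatter; the furthest is compound 1, at 588 nM.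

Compound 4 `CCCCc1cnc(CCc2ccc(-c3ccccc3C(=O)O)cc2)[nH]1` is not yet measured. Relative to compound 3 the change is propyl in place of 4-cyanophenyl on a saturated chain carbon bound to an aromatic carbon; seen one bond further out, this reads 4-cyanobenzyl to butyl.

Going by the values given here, one measured step bears on this. It is a 10-fold higher number from compound 1 to compound 3 (1.00 log units; beyond the scatter), where a small saturated group on that chain carbon was exchanged for the 4-cyanophenyl and the number rose. Compound 4 moves the other way, from the 4-cyanophenyl back to a small saturated group, propyl. Among the compounds with values here, compound 2 also carries butyl on the imidazole, though with an additional butyl branch on the linker, so its value of 2660 nM is only an indirect guide, with no single-place step to compound 4.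

Compound 4 is therefore expected to give a lower number than compound 3, a step of a 7.4-fold lower number from compound 3 to compound 4 (0.87 log units; beyond the scatter), in line with the reverse of the step from compound 1 to compound 3. The estimate for compound 4 is 800 nM, with a range from 250 nM to 2600 nM.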

Compound 4, half-maximal effective concentration: 2710 nM
Beside the measured number, compound 4's estimate is 3.4-fold (0.53 log units) below it; measured number above the stated range.
By their numbers in this assay, from the lowest: compound 1; then compounds 2 and 4 (each within the scatter of the next); then compound 3.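

In this assay, propyl in place of 4-cyanophenyl on a saturated chain carbon bound to an aromatic carbon gives a 2.2-fold lower number from compound 3 to compound 4 (0.34 log units; beyond the scatter), a smaller move than a 10-fold higher number from compound 1 to compound 3 (1.00 log units; beyond the scatter), so a small saturated group at this place does not by itself bring the number back to that of the cyclobutyl member. The choice of saturated group therefore counts here, as exchanging cyclobutyl for propyl gives a 4.6-fold higher number from compound 1 to compound 4 (0.66 log units; beyond the scatter), a change beyond the scatter between two groups that both lack the 4-cyanophenyl. The butyl branch on the linker shows no readable effect in this background: with hydrogen in its place the result is a 1.0-fold higher number from compound 2 to compound 4 (0.01 log units; within the scatter), within the scatter.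

Nothing available gives a reason for the difference between cyclobutyl and propyl at this place. Still open, on these data alone, is whether the lower number goes with the ring of cyclobutyl or with some other feature of that group, which a cyclopentyl group, an isobutyl group or a longer chain at the same carbon could help to separate.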